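A Second Fluoro Group at the Assay Limit

This account rests on a few compounds, and the source may have more. Where it says the series, first, only, none or still open, it means among the compounds named here.

In a functional assay on K562 cells (Homo sapiens) for antiproliferative activity, with a stated time of 72 h (on this read-out lower numbers stand for stronger inhibition and higher numbers for weaker inhibition), compound 1 (`CCCC#Cc1cc([C@@H]2O[C@H](CO)[C@@H](O)[C@H]2O)n2ncnc(N)c12`) gives 1100 nM as a measured number. For compound 2 (`Nc1ncnn2c([C@@H]3O[C@H](CO)[C@@H](O)[C@H]3O)cc(-c3ccc(F)cc3)c12`) the reading > 100000 nM is a limit and not a number. Among the measured compounds shown here, the one measured step is an at least 90-fold higher number from compound 1 to compound 2 (1.95 log units; beyond the scatter) and it is large, yet it exchanges a whole group and does not test a single fluoro group. Compound 3 (`Nc1ncnn2c([C@@H]3O[C@H](CO)[C@@H](O)[C@H]3O)cc(-c3ccc(F)cc3F)c12`) differs from compound 2 by fluoro in place of hydrogen on an aromatic carbon and so carries fluoro in place of hydrogen on an aromatic carbon, turning 4-fluorophenyl into 2,4-difluorophenyl. For the measured compounds named here, no measured step shows such an exchange, so no shift beyond the scatter is expected in this assay and a reading at the limit is likely. The expected step is a number no higher from compound 2 to compound 3 (the limit leaves the size open) and no clear direction is foreseen. For compound 3 the estimated value is 100000 nM within an expected range from 30000 nM to 200000 nM in this read-out.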

Compound 3, half-maximal inhibitory concentration: 69700 nM
Beside the measured number, compound 3's estimate is 1.4-fold (0.16 log units) above it, and the stated range covers the measured number.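

Fluoro in place of hydrogen on the aromatic carbon ortho to a large group gives an at least 1.4-fold lower number from compound 2 to compound 3 (0.15 log units; that floor lies within the scatter), so this second fluoro group brings no change that can be told apart from the scatter in this assay. The reading for compound 2 is a limit and not a number, so the true size of this step stays unknown: the limit of > 100000 nM in this assay, at which 1 of the 3 values shown sits.

Among the compounds shown here, compound 3 does supply the first true number for a fluorinated phenyl group at this position, and with it a firm measure of the gap to the pent-1-yn-1-yl group: a 63-fold higher number from compound 1 to compound 3 (1.80 log units; beyond the scatter).

The compounds shown leave open whether the gap follows from the phenyl ring itself or from its fluoro groups. They also leave open what an unsubstituted phenyl, an amine on that ring or a longer alkyne chain would read here.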